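The source may report more compounds than this note shows. Statements on the series, on what has been measured and on what is new or still open speak of the compounds shown alone.

Measured compounds in an ADME assay on HEK293 cells (Homo sapiens) for inhibition, read by MTT assay, with stated times of 18 h and 4 h; on this read-out higher numbers stand for weaker inhibition and lower numbers for stronger inhibition:
Compound 1 `CCCCCCOP(=O)(O)OCCSC(=S)N1CCCCCC1` gives 70500 nM.
Compound 2 `CCCCCCOP(=O)(O)OCCSC(=S)N1CCN(C)CC1` gives only an assay limit, > 100000 nM.
Compound 3 `CCCOP(=O)(O)OCCSC(=S)N1CCCCCC1` gives 54000 nM.

Compound 1 and compound 2 differ in their cores: 4-methylpiperazin-1-yl in place of azepan-1-yl on a thiocarbonyl carbon. The step between them is an at least 1.4-fold higher number from compound 1 to compound 2 (0.15 log units; that floor lies within the scatter), and its floor is set because of the limit of > 100000 nM in this assay, at which 1 of the 3 values shown sits. From compound 1 to compound 3 the change is hydrogen in place of propyl on a saturated chain carbon, three bonds along the chain from an oxygen on an unsaturated carbon, and the step is a 1.3-fold lower number from compound 1 to compound 3 (0.12 log units; within the scatter), which lies within the scatter.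

Compound 4 `CCCOP(=O)(O)OCCSC(=S)N1CCN(C)CC1` is not yet measured. Against compound 2 it carries the same change, (hydrogen in place of propyl on a saturated chain carbon, three bonds along the chain from an oxygen on an unsaturated carbon), at the same place on the other core. Among the compounds with values here, the step from compound 1 to compound 3 is the only guide, and it was flat. Compound 2 stands at a limit, so the same flat change is expected to leave compound 4 at or near that limit as well; the expected step is a number no higher from compound 2 to compound 4 (the limit leaves the size open). Compound 4 is estimated at 100000 nM, with a range from 50000 nM to 200000 nM, and another limit rather than a number is the likelier outcome.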

Compound 4, half-maximal inhibitory concentration: 39600 nM
Estimate against measurement, compound 4: 2.5-fold (0.40 log units) above; measured number outside the range, below it.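

In this assay the change from hexyl to propyl on the 4-methylpiperazin-1-yl core gives an at least 2.5-fold lower number from compound 2 to compound 4 (0.40 log units; beyond the scatter) and so lies beyond the scatter, whereas on the azepan-1-yl core the same change stayed within it. Compound 2 reads > 100000 nM as a limit of the assay and not a number. Set side by side, the two steps show neither that the change carries over unaltered from one core to the other nor that its size depends on the core: the same change on two cores in this assay, a 1.3-fold lower number (0.12 log units; within the scatter) from compound 1 to compound 3 and an at least 2.5-fold lower number (0.40 log units; beyond the scatter) from compound 2 to compound 4; the limit leaves it open whether they differ.

The compounds shown leave open how a chain shorter than propyl, such as ethyl, or longer than hexyl, such as octyl, would read on either core. They also leave open whether the same change would stay within the scatter or move beyond it with a different amine on the thiocarbonyl carbon, such as morpholine or piperidine.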